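Pentenyl step on the compound 2 chain

This account rests on a few compounds, and the source may have more. Where it says the series, first, only, none or still open, it means among the compounds named here.

Measured in a functional assay on HeLa cells (Homo sapiens) for antiproliferative activity, read by MTT assay, with a stated time of 72 h; a lower number here means a stronger inhibitor, a higher number a weaker inhibitor:
- compound 1 `CCC/C=C/C(=O)Nc1cccc(Oc2nc(Nc3cccc(OC)c3)nc3c2CSCC3)c1`: 33800 nM
- compound 2 `CC/C=C/C(=O)Nc1cccc(Oc2nc(Nc3cccc(C#N)c3)nc3c2CSCC3)c1`: 31800 nM

Compound 2, at 31800 nM, lies within the scatter of compound 1, at 33800 nM, so these two numbers set no order.

Compound 3 `CCC/C=C/C(=O)Nc1cccc(Oc2nc(Nc3cccc(C#N)c3)nc3c2CSCC3)c1` is compound 2 with one change, methyl in place of hydrogen on a saturated chain carbon, two bonds along the chain from a double-bonded chain carbon. Cut one bond further out, it reads but-1-en-1-yl to pent-1-en-1-yl.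

No measured step sizes this change. In this assay, no step beyond the scatter is expected in either direction, and the expectation starts from compound 2 at 31800 nM. The estimated step is a 1.1-fold lower number from compound 2 to compound 3 (0.03 log units; within the scatter). For compound 3 the expected value is 30000 nM, with an estimated range of 15000 nM to 60000 nM.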

Compound 3, half-maximal inhibitory concentration: 7220 nM
For compound 3 the middle estimate is 4.2-fold (0.62 log units) above the measured one; the whole stated range lies above it.
By their numbers in this assay, from the lowest: compound 3; then compounds 2 and 1 (each within the scatter of the next).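

In this assay, this saturated chain carbon, two bonds along the chain from a double-bonded chain carbon, proves sensitive to substitution: methyl in place of hydrogen, which reads but-1-en-1-yl to pent-1-en-1-yl, gives a 4.4-fold lower number from compound 2 to compound 3 (0.64 log units; beyond the scatter) with the nitrile held fixed. With pent-1-en-1-yl held fixed, cyano in place of methoxy on an aromatic carbon gives a 4.7-fold lower number from compound 1 to compound 3 (0.67 log units; beyond the scatter) as a second single-place step, which compound 1 and compound 2 could not separate since they differ in two places. No measurement at hand explains either step.

From the compounds shown here alone, whether a longer chain such as hex-1-en-1-yl or a chain ending in an amine continues, holds or reverses the chain step remains open. Also open, going by these compounds, is whether the chain step carries over when methoxy replaces the nitrile.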